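Notes on removing an aryl methyl in the antiproliferative series

The compounds below may be only part of what the source reports. "The series", "measured", "known", "first", "only" and "open" are said of these compounds alone.

Measured so far:
compound 1 `Cc1c(-c2cc(Cl)cc(Cl)c2)c(C(=O)O)nn1-c1nc(-c2cc(Cl)ccc2F)c(SC(C)C)s1`: 4800 nM
compound 2 `Cc1cc(Cl)cc(-c2c(C)nn(-c3nc(-c4ccc(Cl)c(Cl)c4)c(SC(C)C)s3)c2C(=O)O)c1`: 663 nM
compound 3 `Cc1c(-c2cc(Cl)cc(Cl)c2)c(C(=O)O)nn1-c1nc(-c2cc(Cl)cc(Cl)c2)c(SC(C)C)s1`: 2000 nM

In a functional assay on BJAB cells (Homo sapiens) for antiproliferative activity, with a stated time of 4 days (a higher number here means that more compound is needed for the effect, a lower number that less compound is needed), compound 2 gives the lowest of the three numbers; compound 3 stands beyond the scatter above it, and compound 1 further above still. For the measured compounds named here, the one step measured between single-point variants, a 2.4-fold lower number from compound 1 to compound 3 (0.38 log units; beyond the scatter), is modest and concerns a different site of the shared core, where 3,5-dichlorophenyl replaces 5-chloro-2-fluorophenyl.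

Compound 4 `Cc1nn(-c2nc(-c3ccc(Cl)c(Cl)c3)c(SC(C)C)s2)c(C(=O)O)c1-c1cccc(Cl)c1` differs from compound 2 only at the aryl group carrying the chloro substituent: hydrogen in place of methyl on an aromatic carbon. Going by the values given here, no measured step touches this site or this kind of exchange, so the size of the effect in this assay cannot be read from the data. Loss of one carbon from a small aryl substituent is, on general experience with such series, more often mildly unfavourable than favourable, so a small rise in the number is expected, possibly within the scatter. Compound 4 is therefore estimated at 1000 nM, with a range from 400 nM to 2500 nM. For compound 4 the estimated step is a 1.5-fold higher number from compound 2 to compound 4 (0.18 log units; within the scatter).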

Compound 4, half-maximal effective concentration: 13600 nM
For compound 4 the middle estimate is 14-fold (1.13 log units) below the measured one; the whole stated range lies below it.
By their numbers in this assay, from the lowest: compound 2; then compound 3; then compound 1; then compound 4.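

In this assay, going from 3-chloro-5-methylphenyl to 3-chlorophenyl gives a 21-fold higher number from compound 2 to compound 4 (1.31 log units; beyond the scatter) and so shows that this one methyl, a single carbon on the aromatic ring, matters greatly to the activity of compound 2. This large step also exceeds the modest 2.4-fold lower number from compound 1 to compound 3 (0.38 log units; beyond the scatter) at a different site of the shared core, making the methyl site the more sensitive of the two exchanges seen so far. Nothing on hand accounts for the size of the loss.

Whether methyl is specifically required remains open, as the compounds shown include no ethyl, methoxy or trifluoromethyl group on this carbon. Also unresolved is whether removing the methyl costs as much when the 3,4-dichlorophenyl group of compound 2 is replaced by another aryl group.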